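A ring swap on a chloro-bearing compound

The source may hold more compounds than are shown below. What is called first, only, known or untested is meant among the compounds shown, and "the series" means these compounds.

Compound 1 `CC(=O)N[C@@H]1CCC[C@H](C(=O)Nc2cc(-c3cnc(C)n3C(C)C)ccn2)C1` gives 3.6 mL.min-1.g-1
Compound 2 `CC(=O)N[C@@H]1CCC[C@H](C(=O)Nc2cc(-c3cnc4n3CCCC4)c(Cl)cn2)C1` gives 16 mL.min-1.g-1

In an ADME assay on microsomes from liver (Homo sapiens) for metabolic stability (a higher number here means faster removal of the compound, a lower number slower removal), compound 2 at 16 mL.min-1.g-1 stands highest of the two numbers. Compound 1 stands at 3.6 mL.min-1.g-1 on this scale. The gap between these two compounds lies beyond the scatter. Compound 3 `CC(=O)N[C@@H]1CCC[C@H](C(=O)Nc2cc(-c3cnn4c3CN(C)CC4)c(Cl)cn2)C1` differs from compound 2 by a group of 10 heavy atoms (7 carbon, 3 nitrogen; one five-membered aromatic ring with 2 hetero atoms, one six-membered non-aromatic ring with 2 hetero atoms) in place of a group of 9 heavy atoms (7 carbon, 2 nitrogen; one five-membered aromatic ring with 2 hetero atoms, one six-membered non-aromatic ring with 1 hetero atom), on an aromatic carbon at the place ortho to a chloro group. Among the measured compounds shown here, no measured pair shows such a change, so no step beyond the scatter is expected in this assay, with a slight lean toward a lower number. The estimated 1.5-fold lower number from compound 2 to compound 3 (0.16 log units; within the scatter) stays modest. For compound 3 the expected value is 11 mL.min-1.g-1 within an estimated range of 4.5 mL.min-1.g-1 to 26 mL.min-1.g-1 in this assay.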

Compound 3, intrinsic clearance in microsomes: < 3 mL.min-1.g-1
Compound 3: a limit, no number; the forecaster's own chance of this, stated with the estimate: 5%; middle value at least 3.6-fold (0.56 log units) from the limit.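

Placing the group with a six-membered non-aromatic ring with 2 hetero atoms on the aromatic carbon ortho to a chloro group, in place of the group whose six-membered non-aromatic ring has 1 hetero atom, gives in this assay an at least 5.3-fold lower number from compound 2 to compound 3 (0.72 log units; beyond the scatter). This shows that the read-out at this position responds to a change in the ring group held there. The result for compound 3 is a limit and not a number, so the full size of the step cannot be read: the limit of < 3 mL.min-1.g-1 in this assay, at which 1 of the 3 values shown sits.

Which part of the entering group carries the step stays open. Also open, as far as these compounds go, is how a morpholine or a simple amine on the same carbon would read in this assay.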